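The source may report more compounds than this note shows. Statements on the series, on what has been measured and on what is new or still open speak of the compounds shown alone.

In a functional assay on MCF7 cells (Homo sapiens) for cytotoxicity, read by sulforhodamine B assay, with a stated time of 72 h (on this read-out higher numbers stand for weaker inhibition and lower numbers for stronger inhibition), compound 1 `O=c1sc2cc(Nc3ncnc4c3cnn4-c3ccccc3)ccc2n1Cc1cccc(Br)c1` gives 46100 nM and compound 2 `O=c1sc2cc(Nc3ncnc4c3cnn4-c3ccccc3)ccc2n1Cc1ccc(Cl)cc1Cl` gives 44000 nM, so compound 2 stands level with compound 1 within the scatter. Compound 3 `O=c1sc2cc(Nc3ncnc4c3cnn4-c3ccccc3)ccc2n1Cc1ccc(Cl)c(Cl)c1` differs from compound 2 by one change: 3,4-dichlorophenyl in place of 2,4-dichlorophenyl on a saturated chain carbon bound to an aromatic nitrogen. Among the measured compounds shown here, the only measured step bearing on it is a 1.0-fold lower number from compound 1 to compound 2 (0.02 log units; within the scatter), which also exchanges the substituted phenyl on a saturated chain carbon bound to an aromatic nitrogen and stays within the scatter. The expected step is therefore a 1.1-fold lower number from compound 2 to compound 3 (0.04 log units; within the scatter), with no change beyond the scatter anticipated. In this assay, compound 3 is estimated at 40000 nM, with an expected range from 18000 nM to 80000 nM.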

Compound 3, half-maximal inhibitory concentration: 1600 nM
Compound 3: the middle estimate sits 25-fold (1.40 log units) above what was measured, outside the stated range (below it).
By their numbers in this assay, from the lowest: compound 3; then compounds 2 and 1 (each within the scatter of the next).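

On a saturated chain carbon bound to an aromatic nitrogen, the arrangement of the two chlorines matters in this assay: moving to 3,4-dichlorophenyl gives a 28-fold lower number from compound 2 to compound 3 (1.44 log units; beyond the scatter) with the same atoms joined differently, although the earlier exchange at this place stayed within the scatter. Replacing 3-bromophenyl with 3,4-dichlorophenyl likewise gives a 29-fold lower number from compound 1 to compound 3 (1.46 log units; beyond the scatter) and sets compound 3 apart from the other two. No available evidence explains this difference. The compounds shown leave open whether 4-chlorophenyl or 3-chlorophenyl alone would match 3,4-dichlorophenyl. They also leave open how a longer chain on the aromatic nitrogen would fare.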